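The source may report more compounds than this note shows. Statements on the series, on what has been measured and on what is new or still open speak of the compounds shown alone.

Working notes on the series. In an assay on CHO cells for displacement of a labelled ligand from adenosine receptor A3 (Homo sapiens), with a stated time of 60 min, tested at 10 uM (on this read-out lower numbers stand for less inhibition and higher numbers for more inhibition at the one concentration tested (going by the name of the read-out)), compound 2 `O[C@@H]1[C@H](O)CS[C@H]1Cn1cnc2c(NCc3cccc(Br)c3)ncnc21` gives 6.1% and compound 1 `O[C@@H]1[C@H](O)CS[C@H]1Cn1cnc2c(NCc3cccc(Cl)c3)ncnc21` gives 8.9%; the step of a number 2.8 percentage points lower from compound 1 to compound 2 (within the scatter) lies within the scatter, so the two numbers stand together and neither is set apart from the other. Compound 3 `O[C@@H]1[C@H](O)CS[C@H]1Cn1cnc2c(NCc3cccc(I)c3)ncnc21` carries iodo in place of bromo on an aromatic carbon. Going by the values given here, the only measured step that bears on this change is a number 2.8 percentage points lower from compound 1 to compound 2 (within the scatter), which was within the scatter; no step beyond the scatter is therefore expected from compound 2 to compound 3 in this assay. The expected step is a number 0.1 percentage points lower from compound 2 to compound 3 (within the scatter). The estimate for compound 3 is 6%, with a range from 0% to 15%.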

Compound 3, a percentage reported as inhibition, at one concentration (the size of the read-out at that concentration, not a potency): 13.9%
Beside the measured number, compound 3's estimate is 7.9 percentage points below it; low and high end bracket the measured number.
By their numbers in this assay, from the lowest: compounds 2, 1 and 3 (each within the scatter of the next).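

In this assay, iodo at this position gives a number 7.8 percentage points higher from compound 2 to compound 3 (within the scatter) and a number 5 percentage points higher from compound 1 to compound 3 (within the scatter), so the step from either of the other two halogens stays within the scatter. Chloro, bromo and iodo on this aromatic carbon therefore stand together, and the change from 3-bromobenzyl to 3-iodobenzyl sets no compound apart. No other data bear on these numbers. The compounds shown leave open whether any group at this position moves the read-out beyond the scatter. An amine, a carboxylic acid or a methoxy group in place of the halogen remains an open case.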